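Chloro in place of pyridin-4-yl

A few compounds are considered here, and "the series" means these few. Any claim that something is new, unique, unknown or untested is made for them only; others in the source may bear on it.

Among the measured compounds shown here, in a functional assay on KG-1 cells (Homo sapiens) for cytotoxicity, read by luminescence and CellTiter-Glo, with a stated time of 3 days (a lower number here means a stronger inhibitor, a higher number a weaker inhibitor), compound 1 `N#Cc1ccc(NC(=O)c2cc(-c3ccncc3)ccc2O)cc1` gives 7990 nM and stands as the higher of the two numbers measured so far. Compound 2 `N#Cc1ccc(NC(=O)c2ccc(C(F)(F)F)cc2O)cc1` gives 1440 nM and lies lower, beyond the scatter. For the measured compounds named here, no measured pair differs in one place only, so no direct step is available as a guide.

Compound 3 `N#Cc1ccc(NC(=O)c2cc(Cl)ccc2O)cc1` keeps the core of compound 1 and carries chloro in place of pyridin-4-yl on an aromatic carbon, para to a hydroxy group (chloro in place of pyridin-4-yl on an aromatic carbon). Going by the values given here, the only hint comes from compound 2, which also has no pyridin-4-yl and reads 1440 nM on this scale. That is thin support from a single compound. The expected step is a 4.4-fold lower number from compound 1 to compound 3 (0.65 log units; beyond the scatter) and points to a lower number, beyond the scatter. For compound 3 the estimate is 1800 nM with 500 nM to 6000 nM as the expected range.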

Compound 3, half-maximal inhibitory concentration: 1860 nM
The estimate for compound 3 lay 1.0-fold (0.01 log units) below the measured number; low and high end bracket the measured number.
By their numbers in this assay, from the lowest: compounds 2 and 3 (each within the scatter of the next); then compound 1.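

In this assay, among the compounds shown here, chloro in place of pyridin-4-yl on the aromatic carbon para to a hydroxy group gives a 4.3-fold lower number from compound 1 to compound 3 (0.63 log units; beyond the scatter) and is the first change that can be read in one place alone. The number at this position therefore depends on the group it carries, and the six-membered aromatic ring of pyridin-4-yl is not required for activity here, as a single chlorine atom gives the lower number. Nothing measured here accounts for this step.

A single pair cannot separate the effect of removing pyridin-4-yl from the effect of adding chloro. Going by these compounds, it also remains open whether hydrogen, fluoro, methyl, an amine or a carboxylic acid at this position would move the number in the same direction.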